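The compounds below may be only part of what the source reports. "The series", "measured", "known", "first", "only" and "open" are said of these compounds alone.

Compound 1 `Cc1ccc(OCc2ccccc2)c(C(C)NC(=O)NS(=O)(=O)c2ccc(Cl)cc2)c1`: 65300 nM
Compound 2 `CC(NC(=O)NS(=O)(=O)c1ccc(Cl)cc1)c1ccccc1OCc1ccccc1`: 157000 nM
Compound 3 `Cc1ccc(S(=O)(=O)NC(=O)NC(C)c2ccccc2OCc2ccccc2)cc1`: > 200000 nM (a limit)

The measurements come from a functional assay on thoracic aorta (Rattus norvegicus, strain Wistar), with a stated time of 15 min; on this read-out higher numbers stand for an effect only at larger amounts of compound and lower numbers for an effect already at smaller amounts. Among the two true numbers, compound 2 stands highest at 157000 nM. Compound 3 gives only a limit, > 200000 nM. Compound 4 `CC(NC(=O)N(C)S(=O)(=O)c1ccc(Cl)cc1)c1ccccc1OCc1ccccc1` departs from compound 2 by one change, methyl in place of hydrogen on an amide-type nitrogen whose other neighbours are the carbonyl carbon and the sulfonyl sulfur.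

Going by the values given here, no measured step touches this nitrogen. The two available steps both lie on an aromatic carbon: a 2.4-fold higher number from compound 1 to compound 2 (0.38 log units; beyond the scatter), and an at least 1.2-fold higher number from compound 2 to compound 3 (0.10 log units; that floor lies within the scatter). They are therefore only a loose guide, showing modest movement in this assay and no large jump. The scale also ends near this region, with the limit of > 200000 nM in this assay, at which 1 of the 3 values shown sits.

On that basis, no change beyond the scatter is expected, with only a slight lean towards a higher number. The expected step is a 1.1-fold higher number from compound 2 to compound 4 (0.06 log units; within the scatter). For compound 4 the estimate is 180000 nM, with an expected range of 70000 nM to 400000 nM.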

Compound 4, half-maximal effective concentration: 38400 nM
Beside the measured number, compound 4's estimate is 4.7-fold (0.67 log units) above it; measured number outside the range, below it.
By their numbers in this assay, from the lowest: compounds 4 and 1 (each within the scatter of the next); then compound 2. At a limit, above all of these: compound 3.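

In this assay, the amide-type nitrogen whose other neighbours are the carbonyl carbon and the sulfonyl sulfur proves to be a place where a small change moves the number: methyl in place of hydrogen gives a 4.1-fold lower number from compound 2 to compound 4 (0.61 log units; beyond the scatter). The earlier steps shown here all lay on an aromatic carbon and said nothing about this nitrogen, whereas this step shows an effect already at smaller amounts of compound once the methyl is present. It also moves away from the end of the scale: the limit of > 200000 nM in this assay, at which 1 of the 4 values shown sits.

From the compounds shown here alone, whether this step comes from the methyl itself or from the loss of the amide hydrogen stays open, and an ethyl group or a longer chain on this nitrogen could help to separate the two. Going by these compounds, it also remains open whether the same step would hold in compound 1 or compound 3.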